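A few compounds are considered here, and "the series" means these few. Any claim that something is new, unique, unknown or untested is made for them only; others in the source may bear on it.

Compound 3 `C=CCNC(=O)/C(C)=C(\C)c1ccc(OC)cc1` and compound 4 `C=CCNC(=O)/C(C)=C(/C)c1ccc(OC)cc1` share their atoms and bonds; (the two compounds have the same atoms and bonds and differ only in configuration as drawn: 1 of 1 stereo elements differ; a double bond is drawn E in compound 3 and Z in compound 4). In a toxicity assay on the whole organism (strain Icem-CET (SPF Caw)) for cytotoxicity, with Mus musculus as the target (a lower number here means that less compound is needed, a higher number that more compound is needed for the effect), compound 3 gives 300 mg/kg, a number that sits within the usual scatter of those of compound 1 `C=CCNC(=O)/C(C)=C(/C)c1ccc(Cl)cc1`, which gives 400 mg/kg, and of compound 2 `C=CCNC(=O)/C(C)=C(/C)c1ccc(C)cc1`, which gives 400 mg/kg. For the measured compounds named here, the only step between measured compounds, no change at the digits printed from compound 1 to compound 2 (within the scatter), concerns a ring substituent and not the geometry of the double bond, so no measured step bears directly on the change from compound 3 to compound 4. With nothing in this set pointing either way, the number for compound 4 is expected to stay within the scatter of compound 3, the expected step being no change at the digits printed from compound 3 to compound 4 (within the scatter). Compound 4 is therefore estimated at 300 mg/kg, in a range from 150 mg/kg to 600 mg/kg.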

Compound 4, dose for half-maximal effect: 400 mg/kg
Estimate against measurement, compound 4: 1.3-fold (0.12 log units) below; measured number inside the range.
By their numbers in this assay, from the lowest: compounds 3, 1, 2 and 4 (each within the scatter of the next).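

In this assay the change of double-bond geometry gives a 1.3-fold higher number from compound 3 to compound 4 (0.12 log units; within the scatter) and so stays inside the scatter for this methoxy pair: the fact that compounds 3 and 4 differ only in the configuration as drawn. With the geometry drawn as in compounds 1 and 2, methoxy also matches chloro and methyl on the aromatic carbon, giving no change at the digits printed from compound 2 to compound 4 (within the scatter) and no change at the digits printed from compound 1 to compound 4 (within the scatter). From the compounds shown here alone, whether the geometry step would stay this small with chloro or methyl on the ring remains open, as does whether a carboxylic acid or an amine in place of methoxy would carry the number beyond the scatter.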